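All ortho swaps on the aryl urea leave the readout flat

This account rests on a few compounds, and the source may have more. Where it says the series, first, only, none or still open, it means among the compounds named here.

Three aryl ureas sharing one core differ only in the group on an aromatic carbon of the aniline ring. Compound 1 `Cc1ccccc1NC(=O)N[C@H](C)c1ccccc1` gives 100% in an ADME assay on the whole organism with Oryza sativa as the target, tested at 1 uM; a higher number here means a weaker effect of the compound at the concentration tested, a lower number a stronger effect. Compound 2 `C[C@@H](NC(=O)Nc1ccccc1C(F)(F)F)c1ccccc1` gives 95%, and compound 3 `COc1ccccc1NC(=O)N[C@H](C)c1ccccc1` gives 105%, the largest of the three numbers, though each other value lies within the scatter of it. The change of trifluoromethyl in place of methyl gave a number 5 percentage points lower from compound 1 to compound 2 (within the scatter), methoxy in place of methyl gave a number 5 percentage points higher from compound 1 to compound 3 (within the scatter), and methoxy in place of trifluoromethyl gave a number 10 percentage points higher from compound 2 to compound 3 (within the scatter). Compound 4 `C[C@@H](NC(=O)Nc1ccccc1Br)c1ccccc1` is still to be measured; it differs from compound 3 by bromo in place of methoxy on an aromatic carbon. Every measured exchange at this same aromatic carbon stayed within the scatter, so compound 4 is expected to show a number 5 percentage points lower from compound 3 to compound 4 (within the scatter), a step not beyond the scatter. On that basis compound 4 is estimated to give 100%, with a range from 88% to 112%.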

Compound 4, a percentage reported as activity, at one concentration (the size of the read-out at that concentration, not a potency): 100%
Compound 4: middle estimate and measured number agree at the digits printed, within the range that was stated.
By their numbers in this assay, from the lowest: compounds 2, 1, 4 and 3 (each within the scatter of the next).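

Bromo brings a single heavy atom and no hydrogen-bond acceptor to this aromatic carbon, ortho to a large group, and this assay still does not separate it from the other groups: bromo in place of methoxy gives a number 5 percentage points lower from compound 3 to compound 4 (within the scatter), bromo in place of trifluoromethyl gives a number 5 percentage points higher from compound 2 to compound 4 (within the scatter), and bromo in place of methyl gives no change at the digits printed from compound 1 to compound 4 (within the scatter). All four compounds now lie within the scatter of one another, so no exchange at this carbon has yet moved the read-out beyond it. Nothing available bears on why the read-out stays flat here.

On these data alone, whether an amine, a carboxylic acid or a nitrile at this carbon would move the number beyond the scatter stays open. So does whether any change elsewhere in the shared core would do so.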